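The source may report more compounds than this note shows. Statements on the series, on what has been measured and on what is new or still open speak of the compounds shown alone.

Of the compounds shown here, three have been measured in a functional assay on Jurkat cells (Homo sapiens) for inhibition, read by CCK-8 assay, with a stated time of 48 h; a higher number here means a weaker inhibitor of growth, a lower number a stronger inhibitor of growth. Compound 1 `Cc1ccccc1Nc1nc(Nc2cccnc2)ncc1Cl` gives 38600 nM, compound 2 `Cc1ccccc1Nc1nc(Nc2ccc(N3CCN(C)CC3)cc2)ncc1Cl` gives 13700 nM, and compound 3 `COc1ccccc1CNc1nc(Nc2ccc(N3CCN(C)CC3)cn2)ncc1Cl` gives 10800 nM. Compound 3 carries the lowest number of the three: its gap to compound 2 lies within the usual scatter of this kind of measurement, while its gap to compound 1 lies beyond it. Compound 4 `COc1cccc(Nc2nc(Nc3ccc(N4CCN(C)CC4)cn3)ncc2Cl)c1` has not yet been measured. It differs from compound 3 in one place: 3-methoxyphenyl in place of 2-methoxybenzyl on a nitrogen on an aromatic ring. Within the data shown here, no measured pair shows this change directly, so its effect cannot be read from the numbers at hand. The step of a 1.2-fold lower number from compound 3 to compound 4 (0.08 log units; within the scatter) is expected to stay within the scatter. The estimate for compound 4 in this assay is 9000 nM, with a range from 3000 nM to 30000 nM.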

Compound 4, concentration for 50% growth inhibition: 15800 nM
Estimate against measurement, compound 4: 1.8-fold (0.24 log units) below; the range from low to high includes it.
By their numbers in this assay, from the lowest: compounds 3, 2 and 4 (each within the scatter of the next); then compound 1.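

In this assay, among these compounds, putting 3-methoxyphenyl in place of 2-methoxybenzyl on a nitrogen on an aromatic ring gives a 1.5-fold higher number from compound 3 to compound 4 (0.17 log units; within the scatter) and so offers the first direct reading of a change at this place. The assay does not separate the two groups, although the change alters the group on that nitrogen from (2-methoxybenzyl)amino to (3-methoxyphenyl)amino. No measured evidence bears on this result. On these data alone, whether the methoxy group matters at all remains open, as does whether a cyclohexyl group or a carboxylic acid on that nitrogen would move the number beyond the scatter.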